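The source may report more compounds than this note shows. Statements on the series, on what has been measured and on what is new or still open speak of the compounds shown alone.

Three compounds built on one shared core, each carrying the same unsaturated side chain, have been tested in a functional assay on DLD-1 cells (Homo sapiens) for cytotoxicity, with a stated time of 48 h; on this read-out higher numbers stand for weaker inhibition and lower numbers for stronger inhibition. Compound 1 `CC(C)CC(=O)Oc1ccc2oc(/C=C/[S+](C)[O-])cc(=O)c2c1` gives 6100 nM. Compound 2 `Cc1cccc2c(=O)cc(/C=C/[S+](C)[O-])oc12` gives 6800 nM, and compound 3 `Cc1cccc2oc(/C=C/[S+](C)[O-])cc(=O)c12` gives 5500 nM. All three numbers lie within the usual scatter of one another, so compound 1 cannot be set apart from compound 2 or compound 3 on these values, and none of the gaps between them goes beyond that scatter.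

Compound 4 `C[S+]([O-])/C=C/c1cc(=O)c2cc(OC(=O)C(C)(C)C)ccc2o1` has not yet been measured. It differs from compound 1 in one place: tert-butyl in place of isobutyl on a carbonyl carbon. The two compounds have the same atoms, joined differently, and the change sits on a carbonyl carbon rather than on the shared core.

Among the compounds with values here, no measured pair shows what this kind of change does here. Since the three measured compounds, which vary on the core, all give similar numbers, the step expected is a 1.0-fold lower number from compound 1 to compound 4 (0.01 log units; within the scatter), a step staying within the scatter. Compound 4 is estimated at 6000 nM, with a range from 3000 nM to 12000 nM.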

Compound 4, half-maximal inhibitory concentration: 8000 nM
For compound 4 the middle estimate is 1.3-fold (0.12 log units) below the measured one; measured number inside the range.
By their numbers in this assay, from the lowest: compounds 3, 1, 2 and 4 (each within the scatter of the next).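

Moving from isobutyl to tert-butyl on a carbonyl carbon gives a 1.3-fold higher number from compound 1 to compound 4 (0.12 log units; within the scatter) in this assay, so this rearrangement of the same atoms has no readable effect on the number. Within the data shown here, the earlier compounds varied on the shared core and offered no pair for judging a change at this place; this pair is the first, and it shows that these two branched groups cannot be told apart here. The data offer no measurement that could explain the cell result.

As far as these compounds go, it remains open whether a group of a different kind on this carbonyl carbon, such as a longer chain, a phenyl ring or an amine, would move the number beyond the scatter. From the compounds shown here alone, it is also open what a plain hydroxyl group would do in place of the whole (isobutylcarbonyl)oxy group.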